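Propyl in place of isopropyl on compound 1

The source may report more compounds than this note shows. Statements on the series, on what has been measured and on what is new or still open speak of the compounds shown alone.

Values in a functional assay on NCI-H1299 cells (Homo sapiens) for inhibition, read by luminescence and CellTiter-Glo, with a stated time of 3 days; a lower number here means a stronger inhibitor, a higher number a weaker inhibitor:
compound 1 `CC(C)c1cc2cnc(Nc3ccc(N4CCN(C)CC4)cc3)nc2n1-c1cccc(C(C)(C)O)n1`: 91 nM
compound 2 `CN1CCN(C2CCN(c3ccc(Nc4ncc5c(F)c(C6CC6)n(-c6cccc(C(C)(C)O)n6)c5n4)cc3F)CC2)CC1`: 623 nM
compound 3 `CN1CCC2(CC1)CCN(c1ccc(Nc3ncc4cc(C5CC5)n(-c5cccc(C(C)(C)O)n5)c4n3)cc1)CC2`: 199 nM

Compound 1 has the lowest number of the three in this assay, which makes it the strongest inhibitor measured so far. Compound 3 is its nearest neighbour and compound 2 lies furthest away, and both gaps are beyond the scatter.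

The next compound to be read is compound 4 `CCCc1cc2cnc(Nc3ccc(N4CCN(C)CC4)cc3)nc2n1-c1cccc(C(C)(C)O)n1`. It keeps the rest of compound 1 and has propyl in place of isopropyl on an aromatic carbon. The same atoms are present in both, joined differently.

Among the measured compounds shown here, no two measured compounds differ in only one place, so the series gives no direct reading of this change. Compounds 2 and 3 differ from compound 1 in more than one place and say little about it. The expectation therefore starts from compound 1 at 91 nM and allows only a small shift toward a weaker inhibitor, probably within the scatter.

The estimated change is a 1.5-fold higher number from compound 1 to compound 4 (0.19 log units; within the scatter).

For compound 4 the expected value is 140 nM, with an estimated range of 60 nM to 350 nM.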

Compound 4, half-maximal inhibitory concentration: 126 nM
Compound 4: the middle estimate sits 1.1-fold (0.05 log units) above what was measured; the range from low to high includes it.
By their numbers in this assay, from the lowest: compounds 1, 4 and 3 (each within the scatter of the next, the first and the last beyond it); then compound 2.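

In this assay, among the compounds shown here, replacing isopropyl with propyl on the aromatic carbon next to the ring nitrogen gives a 1.4-fold higher number from compound 1 to compound 4 (0.14 log units; within the scatter), the first step that reads a single change at this position. On the core of compound 1, isopropyl and propyl therefore cannot be told apart in this assay, and neither can be ranked above the other. No measurement shown bears on why the two groups read alike.

This single step covers only two chains with the same count of carbons, so it gives no reading of how far the position accepts larger or different groups, and it does not show whether the same swap would behave alike on the other cores in the series. A longer chain such as butyl, or a group of another kind such as a dimethylamino group or a carboxylic acid on this carbon, would test whether the flat reading holds beyond isopropyl and propyl.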